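This account rests on a few compounds, and the source may have more. Where it says the series, first, only, none or still open, it means among the compounds named here.

Measured so far:
- Compound 1, `CC(=O)c1nn(-c2ccc(C)cc2)/c(=N/c2nc(-c3c(C)n(C)n(-c4ccccc4)c3=O)cs2)s1`: 31700 nM
- Compound 2, `COc1ccc(-n2nc(C(C)=O)s/c2=N\c2nc(-c3c(C)n(C)n(-c4ccccc4)c3=O)cs2)cc1`: 41300 nM
- Compound 3, `COc1ccc(/C=C2\S/C(=N\c3nc(-c4c(C)n(C)n(-c5ccccc5)c4=O)cs3)N(c3ccccc3)C2=O)cc1`: 13200 nM

All three were tested in a functional assay on HepG2 cells (Homo sapiens) for cytotoxicity, read by sulforhodamine B assay, with a stated time of 72 h; a higher number here means a weaker inhibitor, a lower number a stronger inhibitor. Compound 1 and compound 2 share a core and differ in one place, (methyl in place of methoxy on an aromatic carbon). That change gave a 1.3-fold lower number from compound 2 to compound 1 (0.11 log units; within the scatter), a step too small to count as a real difference. Compound 3 is built on another core; the difference between the two cores is not broken down here. In this assay compound 3 gives the lowest number of the three, and its gap to compound 1 and to compound 2 lies beyond the scatter.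

The next compound, compound 4, `Cc1ccc(/C=C2\S/C(=N\c3nc(-c4c(C)n(C)n(-c5ccccc5)c4=O)cs3)N(c3ccccc3)C2=O)cc1`, has not yet been measured. It differs from compound 3 by methyl in place of methoxy on an aromatic carbon, the same change already seen between compound 2 and compound 1, made at the same kind of place. Because that earlier step was a 1.3-fold lower number from compound 2 to compound 1 (0.11 log units; within the scatter), the step from compound 3 to compound 4 is expected to be similarly small, a 1.2-fold lower number from compound 3 to compound 4 (0.08 log units; within the scatter). Compound 4 is therefore estimated at 11000 nM in this assay, most likely between 5000 nM and 25000 nM.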

Compound 4, half-maximal inhibitory concentration: > 100000 nM
Compound 4 gave a limit, no number; the forecaster's own chance of this, stated with the estimate: 5%; middle value at least 9.0-fold (0.95 log units) from the limit.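

In this assay compound 4 gives > 100000 nM and this value is a limit of the assay, not a number. Going from 4-methoxyphenyl to 4-methylphenyl gave an at least 7.5-fold higher number from compound 3 to compound 4 (0.87 log units; beyond the scatter) and so the small step seen on the other core did not carry over, as the two steps differ clearly: the same change on two cores in this assay, a 1.3-fold lower number (0.11 log units; within the scatter) from compound 2 to compound 1 and an at least 7.5-fold higher number (0.87 log units; beyond the scatter) from compound 3 to compound 4, at least 9.8-fold (0.99 log units) apart, beyond the scatter of two such steps. This shows that in these two pairs the same change cannot be read across from one core to the other, but it does not show why, how large the step on the core of compound 3 really is, or what would happen on any further core.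

As far as these compounds go, it remains open whether other groups at the same place, such as a fluorine atom, a hydroxyl group or an amine, would keep the number of compound 3 or lose it as methyl does. From the compounds shown here alone, it also remains open whether the methoxy group itself matters on this core, or whether a longer chain such as ethoxy would serve as well.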